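This account rests on a few compounds, and the source may have more. Where it says the series, first, only, none or still open, it means among the compounds named here.

Measured so far:
Compound 1 `COc1ccc(S(=O)(=O)c2nc3ccccc3nc2N2CCc3ccccc3C2)cc1`: in a functional assay on A549 cells (Homo sapiens) for cytotoxicity, read by MTT assay, with a stated time of 72 h (a lower number here means a stronger inhibitor, a higher number a weaker inhibitor), compound 1 gives > 50000 nM, which is a limit of the assay, not a number.
Compound 2 `O=S(=O)(c1ccc(F)cc1)c1nc2ccccc2nc1N1CCc2ccccc2C1`: in this assay compound 2 gives 22900 nM.
Compound 3 `COc1ccc(S(=O)(=O)c2nc3ccccc3nc2N2CCC(O)CC2)cc1`: in this assay compound 3 gives 5110 nM.

Compound 4 `O=S(=O)(c1ccc(F)cc1)c1nc2ccccc2nc1N1CCC(O)CC1` is not yet measured. It differs from compound 3 by fluoro in place of methoxy on an aromatic carbon. The same change occurs from compound 1 to compound 2, (fluoro in place of methoxy on an aromatic carbon), where it gave an at least 2.1-fold lower number from compound 1 to compound 2 (0.33 log units; beyond the scatter); that step is known only as a lower bound because compound 1 sits at the limit of > 50000 nM in this assay, at which 1 of the 3 values shown sits. The two cores differ by 4-hydroxypiperidin-1-yl in place of 1,2,3,4-tetrahydroisoquinolin-2-yl on an aromatic carbon, and the place of the change is worded the same in both pairs, so it is the same change on a different core. From compound 3 to compound 4 a step of similar size is expected, a 2.0-fold lower number from compound 3 to compound 4 (0.31 log units; beyond the scatter), resting on the earlier step from compound 1 to compound 2 and on compound 3 at 5110 nM. Compound 4 is therefore estimated at 2500 nM, with a likely range from 1000 nM to 6000 nM.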

Compound 4, half-maximal inhibitory concentration: 20200 nM
Compound 4: middle estimate off by 8.1-fold (0.91 log units), on the low side; the whole stated range lies below it.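

The swap of methoxy for fluoro does not carry from one core to the other in this assay: the same change on two cores in this assay, an at least 2.1-fold lower number (0.33 log units; beyond the scatter) from compound 1 to compound 2 and a 4.0-fold higher number (0.60 log units; beyond the scatter) from compound 3 to compound 4, at least 8.6-fold (0.93 log units) apart, beyond the scatter of two such steps. On the core of compound 3 it gives a 4.0-fold higher number from compound 3 to compound 4 (0.60 log units; beyond the scatter), and with fluoro in place, changing 1,2,3,4-tetrahydroisoquinolin-2-yl to 4-hydroxypiperidin-1-yl gives a 1.1-fold lower number from compound 2 to compound 4 (0.05 log units; within the scatter), so the effect of each change depends on the other: the same change on two cores in this assay, an at least 9.7-fold lower number (0.99 log units; beyond the scatter) from compound 1 to compound 3 and a 1.1-fold lower number (0.05 log units; within the scatter) from compound 2 to compound 4, at least 8.6-fold (0.93 log units) apart, beyond the scatter of two such steps. Compound 1 gives > 50000 nM, which is a limit of the assay and not a number, and these compounds do not show why the steps differ or whether this dependence extends to other cores.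

From the compounds shown here alone, it remains open whether a chloro group or a nitrile on the aromatic ring would behave like fluoro or like methoxy. Also open, going by these compounds, is how an amine or a carboxylic acid in place of the hydroxy group would behave.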